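Taking the methyl off compound 2

The source may hold more compounds than are shown below. What is called first, only, known or untested is meant among the compounds shown, and "the series" means these compounds.

Measured in an ADME assay on liver for metabolic stability, with Liver microsome (Homo sapiens) as the target, read by LC-MS, using microsomes; on this read-out higher numbers stand for fast clearance and lower numbers for slow clearance:
compound 1 `O=C(NCc1cc(Cl)ccc1-n1cnnn1)[C@@H]1C[C@@H]2C[C@@H]2N1C(=O)[C@H](O)CC1CC1`: < 12 mL.min-1.g-1
compound 2 `Cc1cccc([C@@H](O)C(=O)N2N=CC[C@H]2C(=O)NCc2cc(Cl)ccc2-n2cnnn2)c1`: < 12 mL.min-1.g-1
compound 3 `O=C(NCc1cc(Cl)ccc1-n1cnnn1)[C@@H]1C[C@@H]2C[C@@H]2N1C(=O)[C@H](O)Cn1cccn1`: < 12 mL.min-1.g-1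

Each of these entries is a limit of the assay and not a number. Compound 2 therefore has no exact position, only the limit < 12 mL.min-1.g-1. The whole set looks the same: the limit of < 12 mL.min-1.g-1 in this assay, at which 3 of the 3 values shown sit.

Compound 4 `O=C(NCc1cc(Cl)ccc1-n1cnnn1)[C@@H]1CC=NN1C(=O)[C@H](O)c1ccccc1` differs from compound 2 in a single place: hydrogen in place of methyl on an aromatic carbon. In words, hydrogen takes the place of methyl on an aromatic carbon, turning 3-methylphenyl into phenyl.

Among the compounds with values here, the only measured step available is a step that the two limits leave unreadable from compound 1 to compound 3. It involves a different change and gives no size to carry over, so the data offer no direction for this one. No step beyond the usual scatter is expected in this assay. That expectation rests on compound 2, whose value is the limit < 12 mL.min-1.g-1. The expected step is a step that the limit leaves unreadable from compound 2 to compound 4, and this is only an estimate. The assay may well report a limit again. For compound 4 the estimated value is 8 mL.min-1.g-1, with an expected range of 4 mL.min-1.g-1 to 16 mL.min-1.g-1.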

Compound 4, intrinsic clearance in microsomes: < 12 mL.min-1.g-1
Compound 4 was reported as a limit (the forecaster's own chance of this, stated with the estimate: 85%); the middle value does not contradict the limit.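

No step can be read between compound 2 and compound 4 in this assay, since both entries are limits of the assay and not numbers: the limit of < 12 mL.min-1.g-1 in this assay, at which 4 of the 4 values shown sit.

The compounds shown leave open whether turning 3-methylphenyl into phenyl changes clearance at all, and how the four compounds rank against one another.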